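Swapping hydroxy for bromo on the benzyl ring

The compounds below may be only part of what the source reports. "The series", "measured", "known", "first", "only" and "open" are said of these compounds alone.

For the measured compounds named here, the three compounds measured so far share one core and differ only in the group on the outer benzyl ring. Compound 1 `COc1ccc(CNCc2c(OC)cc(Oc3cccc(Nc4ccccc4)c3)cc2OC)cc1` carries methoxy there and gives 2650 nM in a functional assay on HCT-15 cells (Homo sapiens) for inhibition, read by MTT assay, with a stated time of 72 h; a lower number here means a stronger inhibitor, a higher number a weaker inhibitor. Compound 2 `COc1cc(Oc2cccc(Nc3ccccc3)c2)cc(OC)c1CNCc1ccc(F)cc1` carries fluoro and gives 3640 nM. Compound 3 `COc1cc(Oc2cccc(Nc3ccccc3)c2)cc(OC)c1CNCc1ccc(O)cc1` carries hydroxy and gives 3430 nM, the second highest of the three numbers; its nearest neighbour is compound 2 and its furthest is compound 1, and both gaps fall within the scatter. Every measured step, a 1.4-fold higher number from compound 1 to compound 2 (0.14 log units; within the scatter), a 1.3-fold higher number from compound 1 to compound 3 (0.11 log units; within the scatter) and a 1.1-fold lower number from compound 2 to compound 3 (0.03 log units; within the scatter), stays within the scatter, so changing this one group has so far left the read-out unchanged.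

Compound 4 `COc1cc(Oc2cccc(Nc3ccccc3)c2)cc(OC)c1CNCc1ccc(Br)cc1` continues the series with bromo in place of hydroxy on an aromatic carbon. Going by the values given here, the steps that bear on it are the three exchanges at the same position, none of which moved the number beyond the scatter. The expected step of a 1.1-fold lower number from compound 3 to compound 4 (0.03 log units; within the scatter) is therefore no real change, and compound 4 is estimated at 3200 nM, within a range from 1300 nM to 8000 nM.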

Compound 4, half-maximal inhibitory concentration: 5410 nM
Estimate against measurement, compound 4: 1.7-fold (0.23 log units) below; low and high end bracket the measured number.
By their numbers in this assay, from the lowest: compounds 1, 3, 2 and 4 (each within the scatter of the next, the first and the last beyond it).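

Bromo gives the first step at this position that passes the scatter in this assay: exchanged for methoxy, it gives a 2.0-fold higher number from compound 1 to compound 4 (0.31 log units; beyond the scatter), a modest step. Its other two exchanges stay within the scatter, with a 1.6-fold higher number from compound 3 to compound 4 (0.20 log units; within the scatter) and a 1.5-fold higher number from compound 2 to compound 4 (0.17 log units; within the scatter), so even replacing hydroxy, which has a hydrogen-bond donor and acceptor, with bromo, which has neither, gives no clear difference here. For the compounds shown here, nothing available explains the one step beyond the scatter.

Going by these compounds, whether an amine or a carboxylic acid on this aromatic carbon would give a larger step remains open, as does the effect of a longer chain there. The compounds shown also keep the rest of the shared core fixed, so how changes elsewhere in the molecule would read is unknown.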